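Removing a Methyl Group from a Weak Cell Growth Inhibitor

The source may hold more compounds than are shown below. What is called first, only, known or untested is meant among the compounds shown, and "the series" means these compounds.

In a functional assay on MCF7 cells (Homo sapiens) for inhibition, read by MTT assay, with a stated time of 48 h (on this read-out lower numbers stand for stronger inhibition and higher numbers for weaker inhibition), two compounds of one series have been examined so far. Compound 1 `O=c1cc(-c2ccccc2)oc2ccc(N3COc4c(Br)cc(Br)cc4C3)cc12` is recorded as "not active" (no number reported), with no number attached to it. Among the compounds with values here, compound 2 `Cc1cccc2c1OCN(c1ccc3oc(-c4ccccc4)cc(=O)c3c1)C2` gives 14300 nM in this assay and is thus the only compound of the set with a measured value; it stands alone, with compound 1 noted merely as lacking activity. Compound 3 `O=c1cc(-c2ccccc2)oc2ccc(N3COc4ccccc4C3)cc12` has not yet been measured. It differs from compound 2 in a single place: hydrogen in place of methyl on an aromatic carbon. Within the data shown here, no step between two measured compounds exists to show what this change does in this assay, so the expectation rests on compound 2 alone. Since compound 2 gives 14300 nM, the expected step is a 1.4-fold higher number from compound 2 to compound 3 (0.15 log units; within the scatter), which may lean toward weaker inhibition but is not expected to go clearly beyond the scatter. Compound 3 is accordingly estimated at 20000 nM, with a range from 7000 nM to 60000 nM.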

Compound 3, half-maximal inhibitory concentration: 27500 nM
For compound 3 the middle estimate is 1.4-fold (0.14 log units) below the measured one, within the range that was stated.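

In this assay, hydrogen in place of methyl on this aromatic carbon gives a 1.9-fold higher number from compound 2 to compound 3 (0.28 log units; within the scatter). Within the data shown here, this is the first step that can be read at this position, and it shows that taking away the methyl, a single heavy atom, does not move the number beyond the usual scatter of the read-out, so neither compound can be ranked over the other and the methyl cannot be said to matter in this assay. Nothing at hand bears on why the values of these two compounds lie as they do.

What the compounds shown leave open is whether any group on this aromatic carbon would shift the number clearly beyond the scatter, in either direction: an amine, a methoxy group, a carboxylic acid or a longer chain such as ethyl might or might not do so. Among these compounds, also open is what a single bromine would do here, since compound 1 differs from compound 3 in more than one place and carries no number, which means that no step to it can be read.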